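The compounds below may be only part of what the source reports. "The series", "measured", "known", "first", "only" and "open" are said of these compounds alone.

Measured so far in a functional assay on MCF7 cells (Homo sapiens) for inhibition, read by sulforhodamine B assay, with a stated time of 48 h; on this read-out lower numbers stand for stronger inhibition of growth and higher numbers for weaker inhibition of growth:
compound 1 `CCOC(=O)c1nn(-c2ccccc2)c(-c2ccc(Br)cc2)c1CNC(C)(C)C` gives 74200 nM; > 509000 nM (2 entries)
compound 2 `CC(C)(C)NCc1c(C(=O)O)nn(-c2ccccc2)c1-c1ccc(Br)cc1` gives 293000 nM
compound 3 `COc1ccc(-c2c(CNC(C)(C)C)c(C(=O)O)nn2-c2ccccc2)cc1` gives > 659000 nM

The entry for compound 3 is a limit of this assay, not a number. Within (the several entries of compound 1 in this assay, 74200 nM; > 509000 nM (2 entries)), the repeated entries are likewise limits. For the measured compounds named here, compound 2 therefore stands as the only plain number. Going by the values given here, the single measured step, an at least 2.2-fold higher number from compound 2 to compound 3 (0.35 log units; beyond the scatter), concerns the bromo-bearing ring and does not touch the change now in hand.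

Compound 4 `CC(C)(C)NCc1c(C(=O)O)nn(-c2ccc(Cl)cc2)c1-c1ccc(Br)cc1` differs from compound 2 by chloro in place of hydrogen on an aromatic carbon. Among the compounds with values here, no measured step bears on this change, so no step beyond the scatter is expected; compound 4 is estimated at 250000 nM, range 80000 nM to 700000 nM. The step this implies, a 1.2-fold lower number from compound 2 to compound 4 (0.07 log units; within the scatter), is an estimate only, with a fair chance that this assay returns a limit rather than a number.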

Compound 4, concentration for 50% growth inhibition: 221000 nM
Compound 4: the middle estimate sits 1.1-fold (0.05 log units) above what was measured, and the stated range covers the measured number.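

Phenyl to 4-chlorophenyl is the only change shown at this ring, and in this assay it gives a 1.3-fold lower number from compound 2 to compound 4 (0.12 log units; within the scatter). Chloro at this place, para to a large group, thus returns a plain number rather than a limit, so the series now holds a second measured point on which to compare changes. Nothing in the data shown accounts for this result.

Going by these compounds, it remains open whether an amine, a trifluoromethyl or a carboxylic acid at this place would give a step beyond the scatter. Also open, on these data alone, is whether chloro at this place would read the same on the ester of compound 1.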